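A Benzyl Exchange on the Way to Compound 4

The source may report more compounds than this note shows. Statements on the series, on what has been measured and on what is new or still open speak of the compounds shown alone.

In a functional assay on MCF7 cells (Homo sapiens) for antiproliferative activity, read by MTT assay, with a stated time of 48 h, in the presence of a further agent that is not named here (a higher number here means a weaker inhibitor of growth, a lower number a stronger inhibitor of growth), compound 3 `O=C(NOCc1ccccc1F)c1cn(-c2ccccc2)nc1-c1ccc(Cl)cc1` gives 15100 nM, the highest of the three numbers at hand. Compound 1 `O=C(NOCc1ccc(Cl)cc1Cl)c1cn(-c2ccccc2)nc1-c1ccccc1` gives 9660 nM, which lies within the scatter of compound 3, while compound 2 `COc1ccc(-c2nn(-c3ccccc3)cc2C(=O)NOCc2ccc(Cl)cc2Cl)cc1` gives 2570 nM, which lies beyond it. Within the data shown here, the only measured single-site step, a 3.8-fold lower number from compound 1 to compound 2 (0.58 log units; beyond the scatter), concerns the aryl ring on the shared core and leaves the benzyl part untouched. Compound 4 `O=C(NOCc1ccc(Cl)cc1Cl)c1cn(-c2ccccc2)nc1-c1ccc(Cl)cc1` arises from compound 3 by 2,4-dichlorophenyl in place of 2-fluorophenyl on a saturated chain carbon bound to an oxygen. Among the measured compounds shown here, no measured step bears directly on this exchange of benzyl groups. Compound 4 and compound 1 carry the same 2,4-dichlorobenzyl group and differ only at the other aryl ring, so the reading of compound 1 at 9660 nM serves as the nearest reference, and what a chlorine on that ring does is not shown by any step. For this assay, a step of a 1.6-fold lower number from compound 3 to compound 4 (0.20 log units; within the scatter) is therefore expected, a small lowering that may well stay within the scatter. Compound 4 is estimated at 9500 nM, with a range from 3500 nM to 25000 nM.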

Compound 4, concentration for 50% growth inhibition: 16200 nM
Beside the measured number, compound 4's estimate is 1.7-fold (0.23 log units) below it, and the stated range covers the measured number.
By their numbers in this assay, from the lowest: compound 2; then compounds 1, 3 and 4 (each within the scatter of the next).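

Among these compounds, the exchange of 2-fluorobenzyl for 2,4-dichlorobenzyl gives a 1.1-fold higher number from compound 3 to compound 4 (0.03 log units; within the scatter) in this assay and is the first measured step at this position, where this change stays within the scatter. Among the compounds shown here, on the other aryl ring, chloro in place of hydrogen gives a 1.7-fold higher number from compound 1 to compound 4 (0.22 log units; within the scatter) while chloro in place of methoxy gives a 6.3-fold higher number from compound 2 to compound 4 (0.80 log units; beyond the scatter) and so, of the two changes at that aromatic carbon, only the one involving methoxy lies beyond the scatter. Nothing at hand offers an explanation for either result.

On these data alone, it remains open whether the same benzyl exchange would also stay within the scatter in the presence of the methoxy group of compound 2. Also open, as far as these compounds go, is what an amine or a carboxylic acid on the benzyl ring would do.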